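Bromo for methoxy on the amide-bearing ring

The source may report more compounds than this note shows. Statements on the series, on what has been measured and on what is new or still open speak of the compounds shown alone.

Measured compounds:
compound 1, `COc1cc(C(F)(F)F)cc(C(F)(F)F)c1C(=O)NC1(c2ccccc2)CCCN(CC2CC2)C1`, 380 nM
compound 2, `COc1cc(C(F)(F)F)ccc1C(=O)NC1(c2ccccc2)CCCN(C)C1`, 4800 nM

In an assay on cells for inhibition of sodium- and chloride-dependent glycine transporter 1 (Homo sapiens) (on this read-out higher numbers stand for an effect only at larger amounts of compound and lower numbers for an effect already at smaller amounts), compound 2 gives 4800 nM, the highest of the two numbers; compound 1 gives 380 nM, a difference that lies beyond the scatter. Compound 3, `CN1CCCC(NC(=O)c2ccc(C(F)(F)F)cc2Br)(c2ccccc2)C1`, differs from compound 2 by bromo in place of methoxy on an aromatic carbon. Among the measured compounds shown here, no measured pair shows this change, so its direction cannot be read from the numbers at hand. The step from compound 2 to compound 3 in this assay is expected to stay within the scatter, in either direction. Compound 3 is therefore estimated at 4000 nM, within 1500 nM to 12000 nM.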

Compound 3, half-maximal effective concentration: 300 nM
Compound 3: the middle estimate sits 13-fold (1.12 log units) above what was measured, and the stated range ends above it.
By their numbers in this assay, from the lowest: compounds 3 and 1 (each within the scatter of the next); then compound 2.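

In this assay, bromo in place of methoxy on this aromatic carbon, ortho to a large group and meta to a trifluoromethyl group, gives a 16-fold lower number from compound 2 to compound 3 (1.20 log units; beyond the scatter) on an otherwise unchanged structure. Among the compounds shown here, this is the first direct reading of this position, and it shows that the group held there can move the number well beyond the scatter. No available evidence bears on why the step is this large. The compounds shown leave open whether chloro, methyl or a nitrile on this carbon would give a step of similar size.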